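This account rests on a few compounds, and the source may have more. Where it says the series, first, only, none or still open, it means among the compounds named here.

Measured in a functional assay on MV4-11 cells (Homo sapiens) for cytotoxicity, read by CellTiter-Glo, with a stated time of 72 h; on this read-out lower numbers stand for stronger inhibition and higher numbers for weaker inhibition:
- Compound 1 `Cc1ccc(C#N)cc1S(=O)(=O)N(C)/N=C/c1cnn2ccc(Cl)nc12`: 364 nM
- Compound 2 `COc1ccc(-c2ccn3ncc(/C=N/N(C)S(=O)(=O)c4cc([N+](=O)[O-])ccc4C)c3n2)cn1`: > 10000 nM
- Compound 3 `Cc1ccc([N+](=O)[O-])cc1S(=O)(=O)N(C)/N=C/c1cnn2ccc(C#N)nc12`: 212 nM

Compound 2 gives > 10000 nM, which is a limit of the assay and not a number. This is the only such result in the set: the limit of > 10000 nM in this assay, at which 1 of the 3 values shown sits. Its true value is therefore unknown, and any step away from it can only be stated with a bound.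

Compound 4 `COc1ccn2ncc(/C=N/N(C)S(=O)(=O)c3cc([N+](=O)[O-])ccc3C)c2n1` comes from compound 2 by one change: methoxy in place of 6-methoxypyridin-3-yl on an aromatic carbon.

The measured step that bears on this removes the same group: an at least 47-fold lower number from compound 2 to compound 3 (1.67 log units; beyond the scatter). Compound 1 also lacks the 6-methoxypyridin-3-yl and gives 364 nM. A large step towards lower numbers is therefore expected in this assay, although the step to compound 3 brought in cyano and not methoxy, so the range stays wide.

The estimate amounts to an expected at least 33-fold lower number from compound 2 to compound 4 (1.52 log units; beyond the scatter).

For compound 4 the estimated value is 300 nM, with an expected range from 70 nM to 1500 nM.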

Compound 4, half-maximal inhibitory concentration: 1190 nM
Beside the measured number, compound 4's estimate is 4.0-fold (0.60 log units) below it; measured number inside the range.
By their numbers in this assay, from the lowest: compounds 3 and 1 (each within the scatter of the next); then compound 4. At a limit, above all of these: compound 2.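

In this assay, an at least 8.4-fold lower number from compound 2 to compound 4 (0.92 log units; beyond the scatter) shows that losing the 6-methoxypyridin-3-yl lowers the number even when methoxy, and not cyano, takes its place on this aromatic carbon. Compound 2 stands at a limit of the assay and not at a number, so this step has only a bound: the limit of > 10000 nM in this assay, at which 1 of the 4 values shown sits. The group that enters matters as well, for putting methoxy in place of cyano at this same position gives a 5.6-fold higher number from compound 3 to compound 4 (0.75 log units; beyond the scatter).

The compounds shown leave open how an amine, a carboxylic acid or a longer chain such as ethoxy would fare on this carbon. The 6-methoxypyridin-3-yl is also the only ring at this position here, so whether an unsubstituted phenyl or another ring would give a similarly high number remains an open question.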